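A Methoxy Added to Compound 3 in a Cytotoxicity Test

The source may hold more compounds than are shown below. What is called first, only, known or untested is meant among the compounds shown, and "the series" means these compounds.

Of the compounds shown here, three have been measured in an ADME assay on Huh-7 cells (Homo sapiens) for cytotoxicity, read by MTT assay, with a stated time of 4 h, at 37 degrees C; on this read-out lower numbers stand for higher toxicity in this test and higher numbers for lower toxicity in this test. Compound 1 `CCCOCCNc1nc(Nc2ccccc2)nc2c1cc(-c1c(Cl)cccc1Cl)c(=O)n2C` gives 84700 nM and compound 2 `O=C1Nc2nc(Oc3ccccc3)nc(On3nnc4ccccc43)c2CC1c1ccc(F)cc1` gives 62700 nM. Compound 3 `O=c1[nH]c2nc(Nc3ccccc3)[nH]c(=O)c2cc1-c1ccc(F)cc1` gives 13500 nM, the lowest of the three numbers; its nearest neighbour is compound 2, already beyond the usual scatter, and compound 1 lies furthest from it. Compound 4 `COc1ccc(Nc2nc3[nH]c(=O)c(-c4ccc(F)cc4)cc3c(=O)[nH]2)cc1` has not yet been measured. It differs from compound 3 by methoxy in place of hydrogen on an aromatic carbon, so the anilino becomes (4-methoxyphenyl)amino, the new group sitting para to a large group. For the measured compounds named here, no pair of measured compounds differing in one place exists here, so the size of such a step is unknown. Compound 4 is expected to give 15000 nM in this assay, between 5000 nM and 45000 nM. The resulting step, a 1.1-fold higher number from compound 3 to compound 4 (0.05 log units; within the scatter), is expected to stay within the usual scatter.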

Compound 4, half-maximal cytotoxic concentration: 46000 nM
The estimate for compound 4 lay 3.1-fold (0.49 log units) below the measured number, outside the stated range (above it).
By their numbers in this assay, from the lowest: compound 3; then compounds 4, 2 and 1 (each within the scatter of the next).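

For the compounds shown here, the change from anilino to (4-methoxyphenyl)amino gives the first step that can be read in this assay, and it shows that this position is not indifferent: a 3.4-fold higher number from compound 3 to compound 4 (0.53 log units; beyond the scatter) stands beyond the scatter and points towards lower toxicity in this test. No evidence here bears on why the number moved.

Whether the step is particular to methoxy stays open, as a hydroxyl, a fluorine or an ethoxy at this place is not among the compounds shown. As far as these compounds go, it is also open whether methoxy would have a similar effect elsewhere on this ring.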